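The source may report more compounds than this note shows. Statements on the series, on what has been measured and on what is new or still open speak of the compounds shown alone.

Measured so far:
Compound 1, `Cc1oc(-c2ccccc2Cl)nc1CN1CCC(C(=O)NCCCN2C[C@H](C)C[C@H](C)C2)CC1`: 16500 nM
Compound 2, `COc1cccc(Br)c1-c1nc(CN2CCC(C(=O)NCCCN3C[C@H](C)C[C@H](C)C3)CC2)c(C)o1`: 14900 nM

Both numbers come from an ADME assay on Huh7.5.1 cells (Homo sapiens) for cytotoxicity, read by ATP content, with a stated time of 48 h; on this read-out lower numbers stand for higher toxicity in this test and higher numbers for lower toxicity in this test. Compound 2 holds the lower of the two numbers, but compound 1 sits within the scatter of it, so the two cannot be told apart. Within the data shown here, the only measured step, a 1.1-fold lower number from compound 1 to compound 2 (0.04 log units; within the scatter), exchanged the group on one aromatic carbon of the shared core and left the number essentially where it was.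

Compound 3, `COc1ccc(-c2nc(CN3CCC(C(=O)NCCCN4C[C@H](C)C[C@H](C)C4)CC3)c(C)o2)cc1OC`, has not yet been measured. It differs from compound 2 in one place: 3,4-dimethoxyphenyl in place of 2-bromo-6-methoxyphenyl on an aromatic carbon. The step from compound 1 to compound 2 is the only one that bears on this. It also exchanged the group on the same aromatic carbon, and it stayed within the scatter. On that basis the step of a 1.0-fold higher number from compound 2 to compound 3 (0.02 log units; within the scatter) is expected to stay within the scatter too, in no particular direction. Compound 3 is therefore estimated at 15500 nM, with a range from 7500 nM to 32000 nM.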

Compound 3, half-maximal cytotoxic concentration: 57200 nM
Compound 3: middle estimate off by 3.7-fold (0.57 log units), on the low side; measured number above the stated range.
By their numbers in this assay, from the lowest: compounds 2 and 1 (each within the scatter of the next); then compound 3.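

The earlier pair hinted that swapping the aromatic group at this place changes little in this assay, but the 3,4-dimethoxyphenyl group breaks that impression: the result is a 3.8-fold higher number from compound 2 to compound 3 (0.58 log units; beyond the scatter), and likewise a 3.5-fold higher number from compound 1 to compound 3 (0.54 log units; beyond the scatter). Both steps run towards lower toxicity in this test, so the group on this aromatic carbon can shift the number, though only modestly so far, and the two halogen-bearing phenyl groups remain indistinguishable from each other. Nothing available explains why the number moves with this group.

Going by these compounds, the whole aromatic group changes in these steps, so it stays open whether losing the chlorine or bromine, or gaining the two methoxy groups, accounts for the rise. Also open, on these data alone, is whether a phenyl group carrying a single methoxy, an amine or a carboxylic acid would raise the number further or bring it back.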